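This account rests on a few compounds, and the source may have more. Where it says the series, first, only, none or still open, it means among the compounds named here.

Measured in a functional assay on HL-60 cells (Homo sapiens) for antiproliferative activity, read by MTT assay, with a stated time of 48 h; on this read-out lower numbers stand for stronger inhibition and higher numbers for weaker inhibition:

- Compound 1 `CCN(CC)CCCn1c(N)c(-c2nc3ccccc3[nH]2)c2nc(C#N)c(C#N)nc21`: > 730 nM (a limit)
- Compound 2 `CCN(CC)CCCn1c(N)c(-c2nc3ccccc3n2C)c2nc(C#N)c(C#N)nc21`: 2810 nM
- Compound 3 `CCN(CC)CCn1c(N)c(-c2nc3cc(Cl)ccc3[nH]2)c2nc(C#N)c(C#N)nc21`: > 50000 nM (a limit)

Compound 3 stands at a limit, not at a number, and it is the highest figure of the three. Compound 4 `CCN(CC)CCCn1c(N)c(-c2nc3cc(Cl)ccc3[nH]2)c2nc(C#N)c(C#N)nc21` changes its chain from 2-(diethylamino)ethyl to 3-(diethylamino)propyl: (diethylamino)methyl in place of diethylamino on a saturated chain carbon, two bonds along the chain from an aromatic nitrogen.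

Among the compounds with values here, the only measured step, a step that the limit leaves unreadable from compound 1 to compound 2, concerns a methyl on an aromatic nitrogen, so it says nothing direct about this chain. Compound 2 carries the longer chain and gives 2810 nM, so a lower number is expected. The expected change is an at least 16-fold lower number from compound 3 to compound 4 (1.22 log units; beyond the scatter). For compound 4 the estimate is 3000 nM, with an expected range of 400 nM to 30000 nM.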

Compound 4, half-maximal inhibitory concentration: 3470 nM
Compound 4: middle estimate off by 1.2-fold (0.06 log units), on the low side; low and high end bracket the measured number.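

In this assay the move from 2-(diethylamino)ethyl to 3-(diethylamino)propyl gives an at least 14-fold lower number from compound 3 to compound 4 (1.15 log units; beyond the scatter), the first readable sign that this chain length matters at this position. As far as these compounds go, compound 3 stands at a limit, so the true size of that step stays unknown: the limit of > 50000 nM in this assay, at which 1 of the 4 values shown sits. With the longer chain in place, the change of benzimidazole group gives a 1.2-fold higher number from compound 2 to compound 4 (0.09 log units; within the scatter), which lies within the scatter, and the steps from compound 1 cannot be read. The compounds shown leave open how a still longer chain such as 4-(diethylamino)butyl would read. They also leave open what another amine at the chain end, such as morpholine, would do.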